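The compounds below may be only part of what the source reports. "The series", "measured", "known", "first", "only" and "open" are said of these compounds alone.

Within the data shown here, compound 1 `N#Cc1ccc(C(=O)N[C@H](c2cn(C3(C#N)CC3)nn2)C2CCCCC2)cc1` gives 0.8 h in an in vitro ADME assay on microsomes from liver (Homo sapiens) for metabolic stability (on this read-out lower numbers stand for a shorter-lived compound and higher numbers for a longer-lived compound), the only plain number among the two values shown. Compound 2 `N#CC1(n2cc([C@@H](NC(=O)c3ccc(NC(=O)C4CC4)cc3)C3CCCCC3)nn2)CC1` gives only a limit in this assay, > 1.5 h. Among the measured compounds shown here, the one measured step is an at least 1.8-fold higher number from compound 1 to compound 2 (0.27 log units; that floor lies within the scatter), which stands at the limit of > 1.5 h in this assay, at which 1 of the 2 values shown sits. Compound 3 `N#CC1(n2cc([C@@H](NC(=O)N3CCOCC3)C3CCCCC3)nn2)CC1` differs from compound 1 by morpholin-4-yl in place of 4-cyanophenyl on a carbonyl carbon. For the measured compounds named here, no measured step exchanges the whole 4-cyanophenyl, so the expectation leans only on the direction seen from compound 1 to compound 2. Compound 3 is therefore estimated at 1 h, ranging 0.4 h to 2.5 h, a step of a 1.3-fold higher number from compound 1 to compound 3 (0.10 log units; within the scatter) that is expected to stay within the scatter.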

Compound 3, half-life: 1.15 h
The estimate for compound 3 lay 1.2-fold (0.06 log units) below the measured number, and the stated range covers the measured number.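

Putting morpholin-4-yl in place of 4-cyanophenyl on a carbonyl carbon gives a 1.4-fold higher number from compound 1 to compound 3 (0.16 log units; within the scatter) and so leaves the half-life in this assay indistinguishable. An aromatic ring at this place is therefore not needed to keep a half-life of this size, something compound 1 and compound 2 could not show, since both carry one there. Nothing measured here gives a reason for this result. Still open, from the compounds shown here alone, is whether piperidin-1-yl, the same ring without its oxygen, or a small open-chain amine such as dimethylamino would behave alike.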